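Changing the group on the carbonyl of compound 1

The source may report more compounds than this note shows. Statements on the series, on what has been measured and on what is new or still open speak of the compounds shown alone.

Compound 1 `O=C(c1cc(Cl)ccn1)N1CCN(c2nccc(Oc3cc(Cl)cc(Cl)c3)n2)CC1`: 16700 nM
Compound 2 `O=C([C@H]1Cc2ccccc2N1)N1CCN(c2nccc(Oc3cc(Cl)cc(Cl)c3)n2)CC1`: > 50000 nM
Compound 3 `N#Cc1ccc(S(=O)(=O)N2CCN(c3nccc(Oc4cc(Cl)cc(Cl)c4)n3)CC2)cc1`: 24800 nM

In a functional assay on MDA-MB-231 cells (Homo sapiens) for antiproliferative activity, read by MTT assay, with a stated time of 24 h (a higher number here means a weaker inhibitor, a lower number a stronger inhibitor), compound 1 gives 16700 nM and compound 3 gives 24800 nM, two values within the usual scatter of each other. Compound 2 gives > 50000 nM, which is a limit of this assay and not a number. Compound 1 therefore belongs to the better end of this small set, level with compound 3.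

The next compound, compound 4 `O=C(Nc1ccc(C(F)(F)F)cc1)N1CCN(c2nccc(Oc3cc(Cl)cc(Cl)c3)n2)CC1`, keeps the core of compound 1 and has (4-(trifluoromethyl)phenyl)amino in place of 4-chloropyridin-2-yl on a carbonyl carbon.

Among the measured compounds shown here, only one measured step changes the group at this place, namely an at least 2.9-fold higher number from compound 1 to compound 2 (0.47 log units; beyond the scatter). It shows that a swap here can raise the number, but compound 2 carries a different group and its value is only a limit, so it gives a weak guide. The expected change is therefore none beyond the scatter, with real room on both sides: a 1.2-fold higher number from compound 1 to compound 4 (0.08 log units; within the scatter). For compound 4 the estimated value is 20000 nM, with an expected range of 6000 nM to 60000 nM.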

Compound 4, half-maximal inhibitory concentration: 1540 nM
Estimate against measurement, compound 4: 13-fold (1.11 log units) above; measured number below the stated range.
By their numbers in this assay, from the lowest: compound 4; then compounds 1 and 3 (each within the scatter of the next). At a limit, above all of these: compound 2.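

Among the compounds shown here, until now, the only measured step at this place raised the number. In this assay, the new group gives an 11-fold lower number from compound 1 to compound 4 (1.04 log units; beyond the scatter) and thereby shows that a change on this carbonyl carbon can also lower the number by a large margin. The same group gives an at least 32-fold lower number from compound 2 to compound 4 (1.51 log units; beyond the scatter) and widens the gap seen at this place, but the value of compound 2 is a limit and not a number: the limit of > 50000 nM in this assay, at which 1 of the 4 values shown sits.

Compared with 4-chloropyridin-2-yl, (4-(trifluoromethyl)phenyl)amino changes the ring, adds a hydrogen-bond donor and brings in trifluoromethyl in a single step, so these compounds cannot show which of these differences matters. A plain phenylamino group on the same carbonyl carbon would separate the trifluoromethyl group from the rest, and a small methylamino group would test whether the aromatic ring is needed at all.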